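Para-alkyl tail variation in a pyrrolidine amide series

The compounds below may be only part of what the source reports. "The series", "measured", "known", "first", "only" and "open" are said of these compounds alone.

Going by the values given here, compound 1 `Cc1ccc(CCCCCCC(=O)N2CCCC2)cc1` is the only member of the series with a numerical result: in an assay on HEK293 cells for inhibition of N-acylethanolamine-hydrolyzing acid amidase (Rattus norvegicus), read by LC-MS, with a stated time of 30 min (a lower number here means a stronger inhibitor, a higher number a weaker inhibitor), compound 1 gives 9600 nM. Compound 2 `O=C(CCCCCCc1ccccc1Cl)N1CCCC1` reaches only a limit of this assay, > 100000 nM, which is the point noted as the limit of > 100000 nM in this assay, at which 1 of the 2 values shown sits. Compound 3 `CCCc1ccc(CCCCCCC(=O)N2CCCC2)cc1` is not yet measured in this assay; it differs from compound 1 by ethyl in place of hydrogen on a saturated chain carbon bound to an aromatic carbon. With no measured step of this kind in hand, a small step at most is expected, a 1.6-fold lower number from compound 1 to compound 3 (0.20 log units; within the scatter), close to the scatter and without a firm direction. Compound 3 is therefore expected at about 6000 nM, within 2000 nM to 25000 nM.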

Compound 3, half-maximal inhibitory concentration: > 100000 nM
Compound 3: a limit, no number; the forecaster's own chance of this, stated with the estimate: 10%; middle value at least 16-fold (1.22 log units) away from the limit.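

In this assay, lengthening methyl to propyl on the core of compound 1 gives an at least 10-fold higher number from compound 1 to compound 3 (1.01 log units; beyond the scatter), so this position is sensitive to a change of only two carbons. Compound 3 gives a limit, not a number, and the step therefore sets only a minimum size. Only the methyl compound has a numerical result so far: the limit of > 100000 nM in this assay, at which 2 of the 3 values shown sit.

Still open, on these data alone, is how an ethyl group at this place would read, which would show where between methyl and propyl the loss sets in. As far as these compounds go, whether a propyl chain ending in a hydroxyl or a carboxylic acid reads differently is also open.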